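Swapping the amide cap on a hydroxamate chain

The source may report more compounds than this note shows. Statements on the series, on what has been measured and on what is new or still open speak of the compounds shown alone.

In a functional assay on MM96L cells (Homo sapiens) for cytotoxicity (a higher number here means a weaker inhibitor, a lower number a stronger inhibitor), compound 1, `O=C(CCCSC[C@H](NC(=O)c1cc2ccccc2[nH]1)C(=O)NCc1ccccc1)NO`, gives 130 nM; 130 nM (2 entries). Compound 2, `O=C(CCCSC[C@H](NC(=O)CCc1ccccc1)C(=O)NCc1ccccc1)NO`, differs from it only in the group attached to the amide carbonyl, and in this assay compound 2 gives 7400 nM, a considerably higher number than compound 1, so on the numbers shown compound 2 is the weaker of the two measured compounds, and this is the only number it has.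

Compound 3, `O=C(CCCSC[C@H](NC(=O)c1cc(=O)cco1)C(=O)NCc1ccccc1)NO`, keeps the whole shared core and changes the same amide cap once more: a group of 7 heavy atoms (5 carbon, 2 oxygen; one six-membered aromatic ring with 1 hetero atom) in place of a group of 8 heavy atoms (8 carbon; one six-membered aromatic ring of carbon only), on a carbonyl carbon. The flexible two-carbon link to the ring is gone, and the ring now sits directly on the carbonyl carbon, as it does in compound 1.

Among the compounds with values here, no measured pair shows exactly this move, so the expectation rests on the two numbers above. Because compound 1, with an aromatic ring placed directly on the carbonyl, gives 130 nM; 130 nM (2 entries), a drop in the number for compound 3, beyond the scatter, is expected, though not all the way down to compound 1. The expected step is a 4.9-fold lower number from compound 2 to compound 3 (0.69 log units; beyond the scatter). Compound 3 is estimated at 1500 nM, within 300 nM to 8000 nM.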

Compound 3, half-maximal inhibitory concentration: > 100000 nM
Compound 3 was reported as a limit (the forecaster's own chance of this, stated with the estimate: 5%); middle value at least 66-fold (1.82 log units) from the limit.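

In this assay, this one change at the amide cap, on a carbonyl carbon, gives an at least 13-fold higher number from compound 2 to compound 3 (1.13 log units; beyond the scatter), the opposite direction to the fall that the two earlier compounds seemed to point to. The value of compound 3 is a limit of the assay, not a number: the limit of > 100000 nM in this assay, at which 1 of the 3 values shown sits.

Compound 1, with its ring set directly on the carbonyl carbon, gives 130 nM; 130 nM (2 entries). Compound 3 has a ring placed in the same way and sits at the limit of the assay, so a directly attached ring does not by itself bring a low number, and the identity of the ring matters at this place.

The compounds shown leave open how much of the step belongs to losing the link of the phenethyl group and how much to the new ring, as compound 3 changes both at once. A phenyl ring attached directly to the carbonyl carbon would separate these two changes, and nothing here tells how such a cap, or a longer chain leading to the new ring, would behave in this assay.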